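The source may hold more compounds than are shown below. What is called first, only, known or untested is meant among the compounds shown, and "the series" means these compounds.

Working notes on the series. In a functional assay, read by spectrophotometry, with a stated time of 30 min (on this read-out lower numbers stand for stronger inhibition and higher numbers for weaker inhibition), compound 1 (`COC(=O)[C@]1(Cc2ccc3c(c2)C[C@@H](O)C(C)(C)O3)OC(=O)C(O)=C1c1ccc(O)cc1`) gives 135000 nM and compound 2 (`COC(=O)[C@]1(Cc2ccc3c(c2)C[C@H](C(C)(C)O)O3)OC(=O)C(O)=C1c1ccc(O)cc1`) gives 129000 nM; these two numbers lie within the scatter of each other, so compound 1 stands level with compound 2. Compound 3 (`COC(=O)[C@]1(Cc2ccc3c(c2)CCC(C)(C)O3)OC(=O)C(O)=C1c1ccc(O)cc1`) remains unmeasured. It differs from compound 1 by hydrogen in place of hydroxy on a saturated ring carbon. For the measured compounds named here, no measured pair shows this change, so no step beyond the scatter is expected in this assay. The estimated step is a 1.4-fold lower number from compound 1 to compound 3 (0.13 log units; within the scatter). For compound 3 the expected value is 100000 nM, with a range of 40000 nM to 250000 nM.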

Compound 3, half-maximal inhibitory concentration: 97000 nM
Estimate against measurement, compound 3: 1.0-fold (0.01 log units) above, and the stated range covers the measured number.
By their numbers in this assay, from the lowest: compounds 3, 2 and 1 (each within the scatter of the next).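

In this assay, for the compounds shown here, hydrogen in place of hydroxy on a saturated ring carbon gives a 1.4-fold lower number from compound 1 to compound 3 (0.14 log units; within the scatter), the first reading of this position. The hydroxy on this carbon is therefore not needed to hold the read-out at the level of compound 1, and compound 3 stands level with it. No available evidence bears on this result. On these data alone, whether an amine or a carboxylic acid on this ring carbon would shift the number beyond the scatter stays open, as does the effect of replacing the two methyl groups.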